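Acetyl in place of hydrogen: from compound 1 to compound 4

A few compounds are considered here, and "the series" means these few. Any claim that something is new, unique, unknown or untested is made for them only; others in the source may bear on it.

Compound 1 `O=C(/C=C/C(=O)N1C/C(=C\c2ccccc2)C(=O)/C(=C/c2ccccc2)C1)Nc1ccccc1` is the reference point of this set; in a functional assay on Molt4/C8 cells (Homo sapiens) for cytotoxicity (a lower number here means a stronger inhibitor, a higher number a weaker inhibitor), compound 1 gives 520 nM. Two further compounds share the core but differ from compound 1 in more than one place: compound 2 `Cc1ccc(NC(=O)/C=C/C(=O)N2C/C(=C\c3ccc([N+](=O)[O-])cc3)C(=O)/C(=C/c3ccc([N+](=O)[O-])cc3)C2)cc1C` gives 660 nM and compound 3 `Cc1ccc(NC(=O)/C=C/C(=O)N2C/C(=C\c3ccc([N+](=O)[O-])cc3)C(=O)/C(=C/c3ccc([N+](=O)[O-])cc3)C2)cc1` gives 700 nM. Among the measured compounds shown here, the only single-point step among the measured compounds is a 1.1-fold higher number from compound 2 to compound 3 (0.03 log units; within the scatter), hydrogen in place of methyl on an aromatic carbon. Compound 1 has the lowest of the three numbers, yet both gaps to it lie within the scatter, so the three stand together without any order among them.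

Compound 4 `CC(=O)c1ccc(NC(=O)/C=C/C(=O)N2C/C(=C\c3ccccc3)C(=O)/C(=C/c3ccccc3)C2)cc1` differs from compound 1 by acetyl in place of hydrogen on an aromatic carbon. For the measured compounds named here, no measured pair covers an acetyl group; the one step on the same ring, a 1.1-fold higher number from compound 2 to compound 3 (0.03 log units; within the scatter), exchanges hydrogen and methyl without effect beyond the scatter. The expectation is therefore a step of about no change at the digits printed from compound 1 to compound 4 (within the scatter), that is none beyond the scatter. Compound 4 is accordingly estimated at 520 nM, with a range from 250 nM to 1100 nM.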

Compound 4, half-maximal inhibitory concentration: 1400 nM
Estimate against measurement, compound 4: 2.7-fold (0.43 log units) below; the measured number lies above the stated range.
By their numbers in this assay, from the lowest: compounds 1, 2, 3 and 4 (each within the scatter of the next, the first and the last beyond it).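

Acetyl in place of hydrogen on an aromatic carbon, para to a large group, gives a 2.7-fold higher number from compound 1 to compound 4 (0.43 log units; beyond the scatter) in this assay, the first single-place step in the series beyond the scatter. Among the compounds shown here, the only earlier step on this ring, a 1.1-fold higher number from compound 2 to compound 3 (0.03 log units; within the scatter), exchanged methyl and hydrogen on the nitro-bearing compounds, so the new step shows that this ring does not accept every group without a change in the number. No measurement at hand accounts for the step.

Going by these compounds, whether the step belongs to acetyl itself or to any group at this place stays open; an amine, a carboxylic acid or a methoxy group on the same carbon would separate these readings. Also open, on these data alone, is whether acetyl gives a step of like size on the nitro-bearing compounds 2 and 3.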